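This account rests on a few compounds, and the source may have more. Where it says the series, first, only, none or still open, it means among the compounds named here.

In a functional assay on MCF7 cells (Homo sapiens) for inhibition, read by MTT assay, with a stated time of 48 h (a higher number here means a weaker inhibitor, a lower number a stronger inhibitor), compound 3 (`CCCCN(CCCC)C(=O)/C=C/c1c(/C=C/c2ccc(OC)cc2)cc(OC)cc1OC`) gives 3990 nM and stands within the scatter of the other two values: compound 1 (`C#CCNC(=O)/C=C/c1c(/C=C/c2ccc(OC)cc2)cc(OC)cc1OC`) gives 4560 nM and compound 2 (`COc1ccc(/C=C/c2cc(OC)cc(OC)c2/C=C/C(=O)Nc2cc(OC)c(OC)c(OC)c2)cc1`) gives 7010 nM in the same read-out. Compound 4 (`COc1ccc(/C=C/c2cc(OC)cc(OC)c2/C=C/C(=O)N2CCCC(C)C2)cc1`) has 3-methylpiperidin-1-yl in place of dibutylamino on a carbonyl carbon. For the measured compounds named here, two measured steps bear on this change: the replacement on that carbonyl carbon (a 1.1-fold lower number from compound 1 to compound 3 (0.06 log units; within the scatter)) and the replacement on the amide-type nitrogen (a 1.5-fold higher number from compound 1 to compound 2 (0.19 log units; within the scatter)), both within the scatter. No step beyond the scatter is therefore expected in this assay for this replacement. The expected step is small (a 1.1-fold higher number from compound 3 to compound 4 (0.05 log units; within the scatter)). Compound 4 is estimated at 4500 nM (range 2500 nM to 8000 nM).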

Compound 4, half-maximal inhibitory concentration: 11900 nM
Compound 4: middle estimate off by 2.6-fold (0.42 log units), on the low side; the whole stated range lies below it.
By their numbers in this assay, from the lowest: compounds 3, 1, 2 and 4 (each within the scatter of the next, the first and the last beyond it).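

On the carbonyl carbon, the amine part can move the number beyond the scatter in this assay: 3-methylpiperidin-1-yl in place of dibutylamino gives a 3.0-fold higher number from compound 3 to compound 4 (0.47 log units; beyond the scatter) and in place of propargylamino gives a 2.6-fold higher number from compound 1 to compound 4 (0.42 log units; beyond the scatter). The earlier step at this place, dibutylamino in place of propargylamino, stayed within the scatter, so this position is not indifferent to every replacement. Nothing at hand explains the step.

Whether the ring or its methyl accounts for the step remains open. Unsubstituted piperidin-1-yl and morpholin-4-yl on the same carbonyl carbon would help separate the two.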